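Working notes: methoxy to chloro in the acetamide series

The source may hold more compounds than are shown below. What is called first, only, known or untested is meant among the compounds shown, and "the series" means these compounds.

Measured so far:
compound 1 `COc1ccc(-c2cn(CC(=O)Nc3nccs3)nn2)cc1` gives 510 nM
compound 2 `COc1ccc(-c2cn(CC(=O)Nc3nc4ccccc4s3)nn2)cc1` gives 1330 nM
compound 3 `O=C(C1=C(O)C(=O)N(CCCn2ccnc2)[C@@H]1c1cccc(O)c1)c1ccc2c(c1)OCCO2` gives 2700 nM

In a functional assay on BMDM cells (Mus musculus, strain C57BL/6) for inhibition, with a stated time of 2 days (a higher number here means a weaker inhibitor, a lower number a stronger inhibitor), compound 2 stands second highest of the three numbers. The nearest is compound 3, whose number lies beyond the scatter above it; the furthest is compound 1, whose number lies beyond the scatter below it.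

Compound 4 `O=C(Cn1cc(-c2ccc(Cl)cc2)nn1)Nc1nc2ccccc2s1` differs from compound 2 as follows: chloro in place of methoxy on an aromatic carbon. Going by the values given here, no measured pair in this set carries the same change, so its size cannot be read from these data. The expected step is small and close to the scatter, estimated as a 1.1-fold lower number from compound 2 to compound 4 (0.04 log units; within the scatter). Compound 4 is expected near 1200 nM, within a range of 400 nM to 4000 nM.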

Compound 4, half-maximal inhibitory concentration: 130 nM
Compound 4: the middle estimate sits 9.2-fold (0.97 log units) above what was measured, and the stated range ends above it.
By their numbers in this assay, from the lowest: compound 4; then compound 1; then compound 2; then compound 3.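

In this assay, the change from 4-methoxyphenyl to 4-chlorophenyl gives a 10-fold lower number from compound 2 to compound 4 (1.01 log units; beyond the scatter). Going by these compounds alone, this is the only step that can be read so far, and it shows that a single swap on this aromatic carbon, para to a large group, moves the number well beyond the scatter. No measured property bears on why the step is this large.

Going by these compounds, whether the same change carries over to the core of compound 1 remains open. Also open, on these data alone, is how fluoro, bromo or an amine would compare at this position.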